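Compound 1 to compound 4: a larger group on the aromatic nitrogen

The source may hold more compounds than are shown below. What is called first, only, known or untested is meant among the compounds shown, and "the series" means these compounds.

In a functional assay on HCT-116 cells (Homo sapiens) for cytotoxicity, read by MTT assay, with a stated time of 72 h (a lower number here means a stronger inhibitor, a higher number a weaker inhibitor), compound 1 `O=C1c2c[n+]([O-])c3ccccc3c2C(=O)c2c1c1ccccc1n2Cc1cn(C[C@H](O)CO)nn1` gives 400 nM. In the same test compound 2 `CN1CCN(CCCn2c3c(c4ccccc42)C(=O)c2c[n+]([O-])c4ccccc4c2C3=O)CC1` gives 560 nM, and compound 3 `CN(C)CCCCn1c2c(c3ccccc31)C(=O)c1c[n+]([O-])c3ccccc3c1C2=O` gives 450 nM. Compound 1 therefore stands level with the other two: the measured steps are a 1.4-fold higher number from compound 1 to compound 2 (0.15 log units; within the scatter) and a 1.1-fold higher number from compound 1 to compound 3 (0.05 log units; within the scatter), and the remaining one is a 1.2-fold lower number from compound 2 to compound 3 (0.09 log units; within the scatter).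

Compound 4 `O=C1c2c[n+]([O-])c3ccccc3c2C(=O)c2c1c1ccccc1n2Cc1cn([C@@H]2O[C@H](CO)[C@@H](O)[C@H](O)[C@H]2O)nn1` keeps the core of compound 1 and changes one group: 3,4,5-trihydroxy-6-(hydroxymethyl)oxan-2-yl in place of 2,3-dihydroxypropyl on an aromatic nitrogen. The new 3,4,5-trihydroxy-6-(hydroxymethyl)oxan-2-yl takes the place of 2,3-dihydroxypropyl on an aromatic nitrogen of a five-membered aromatic ring with 3 nitrogen. Going by the values given here, no measured step makes this exact exchange. The nearest evidence comes from compound 2 and compound 3, where the whole 1-(2,3-dihydroxypropyl)-1H-1,2,3-triazol-4-yl was replaced, and those steps stayed small: a 1.4-fold higher number from compound 1 to compound 2 (0.15 log units; within the scatter) and a 1.1-fold higher number from compound 1 to compound 3 (0.05 log units; within the scatter). Three compounds are a thin basis, so the expectation is loose, and no step beyond the scatter is expected in this assay. The expected step, leaning slightly upward, is a 1.5-fold higher number from compound 1 to compound 4 (0.18 log units; within the scatter). For compound 4 the estimated value is 600 nM, with an expected range from 250 nM to 1500 nM.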

Compound 4, half-maximal inhibitory concentration: 130 nM
Estimate against measurement, compound 4: 4.6-fold (0.66 log units) above; measured number outside the range, below it.
By their numbers in this assay, from the lowest: compound 4; then compounds 1, 3 and 2 (each within the scatter of the next).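

In this assay, putting 3,4,5-trihydroxy-6-(hydroxymethyl)oxan-2-yl in place of 2,3-dihydroxypropyl on an aromatic nitrogen of the five-membered aromatic ring with 3 nitrogen gives a 3.1-fold lower number from compound 1 to compound 4 (0.49 log units; beyond the scatter), a modest step but the only one among the compounds shown that lies beyond the scatter. Going by these compounds alone, compounds 1, 2 and 3 had stayed within the scatter of one another, even where the whole 1-(2,3-dihydroxypropyl)-1H-1,2,3-triazol-4-yl was exchanged, so compound 4 is the first sign that the number in this test responds to the group at this position. The entering group differs from the leaving one at once in size, in its six-membered ring, in its hydroxyl groups and in its defined stereocentres, and no measurement at hand bears on why the number falls.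

The compounds shown leave open whether the ring or the hydroxyl groups carry the step, a question that an open-chain polyol of the same length would address. They also leave open how the step would hold with a carboxylic acid or an amine in place of the hydroxymethyl on the ring.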